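Swapping One Group on a Compound That Barely Survives

The compounds below may be only part of what the source reports. "The series", "measured", "known", "first", "only" and "open" are said of these compounds alone.

In an ADME assay on cells (Hepatocyte, Homo sapiens) for metabolic stability, with a stated time of 30 min (on this read-out higher numbers stand for a more stable compound and lower numbers for a less stable compound), compound 1 (`NC1CCC(CN2CCN(c3cc(=O)c4cc(C(F)(F)F)cc([N+](=O)[O-])c4s3)CC2)CC1`) gives 83.6% and compound 2 (`O=C(OC1CCC(CN2CCN(c3cc(=O)c4cc(C(F)(F)F)cc([N+](=O)[O-])c4s3)CC2)CC1)c1ccc(C(F)(F)F)cc1`) gives 5.2% as the lower of the two numbers, a gap well beyond the scatter. Compound 3 (`O=C(OC1CCC(CN2CCN(c3cc(=O)c4cc(C(F)(F)F)cc([N+](=O)[O-])c4s3)CC2)CC1)c1ccc(F)cc1`) differs from compound 2 in one place, with fluoro in place of trifluoromethyl on an aromatic carbon. For the measured compounds named here, only this group changes, so compound 3 is expected to stay near the low value of compound 2 (5.2%). The expected step (a number 2.8 percentage points higher from compound 2 to compound 3 (within the scatter)) is small and slightly upward, not beyond the scatter. Compound 3 is estimated at 8% (range 2% to 25%).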

Compound 3, percent of the compound remaining: 3%
Beside the measured number, compound 3's estimate is 5 percentage points above it, and the stated range covers the measured number.
By their numbers in this assay, from the lowest: compounds 3 and 2 (each within the scatter of the next); then compound 1.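

Fluoro in place of trifluoromethyl on this aromatic carbon gives a number 2.2 percentage points lower from compound 2 to compound 3 (within the scatter) in this assay and so leaves the number as low as it was. The large difference comes instead with ((4-fluorophenyl)carbonyl)oxy in place of amino on a saturated ring carbon, which gives a number 80.6 percentage points lower from compound 1 to compound 3 (beyond the scatter) and marks that end of the molecule as the place where the number moves. No measurement here explains either result. From the compounds shown here alone, whether an amine, a carboxylic acid or a longer chain on this aromatic carbon would lift the number remains open.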